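A second fluorine on the aryl ring of compound 2

This account rests on a few compounds, and the source may have more. Where it says the series, first, only, none or still open, it means among the compounds named here.

In a functional assay on CHO cells for agonist activity at metabotropic glutamate receptor 2 (Homo sapiens), read by scintillation counting and GTPgammaS binding, with a stated time of 30 min (on this read-out lower numbers stand for an effect already at smaller amounts and higher numbers for an effect only at larger amounts of compound), compound 2 `COc1ccc(F)cc1C1CCN(c2ccn3c(CC4CC4)nnc3c2Cl)CC1` gives 8.2 nM, the lowest of the three numbers, although compound 1 `COc1ccc(F)cc1C1CCN(c2ccn3c(CC(F)(F)F)nnc3c2Cl)CC1`, at 10.5 nM, lies within the scatter of it. Compound 3 `COc1c(C2CCN(c3ccn4c(CC5CC5)nnc4c3Cl)CC2)ccc(F)c1F` gives 26 nM. Compound 4 `COc1c(F)ccc(F)c1C1CCN(c2ccn3c(CC4CC4)nnc3c2Cl)CC1` carries 3,6-difluoro-2-methoxyphenyl in place of 5-fluoro-2-methoxyphenyl on a saturated ring carbon. For the measured compounds named here, two measured steps bear on this: a 1.3-fold lower number from compound 1 to compound 2 (0.11 log units; within the scatter), which changed a group far from the aryl ring and stayed within the scatter, and a 3.2-fold higher number from compound 2 to compound 3 (0.50 log units; beyond the scatter), the only step that altered the aryl ring, which lost modestly. The change to compound 4 again moves fluorine on that ring, so a step of similar size and direction is expected, a 3.0-fold higher number from compound 2 to compound 4 (0.48 log units; beyond the scatter). Compound 4 is therefore estimated at 25 nM, with a range from 8 nM to 80 nM.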

Compound 4, half-maximal effective concentration: 7.5 nM
The estimate for compound 4 lay 3.3-fold (0.52 log units) above the measured number, and the stated range ends above it.
By their numbers in this assay, from the lowest: compounds 4, 2 and 1 (each within the scatter of the next); then compound 3.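

Adding a second fluorine to this aryl ring does not have to raise the number: in this assay, the change to 3,6-difluoro-2-methoxyphenyl gives a 1.1-fold lower number from compound 2 to compound 4 (0.04 log units; within the scatter). Where the two fluorines stand on the ring therefore matters, since exchanging 3,4-difluoro-2-methoxyphenyl for 3,6-difluoro-2-methoxyphenyl gives a 3.5-fold lower number from compound 3 to compound 4 (0.54 log units; beyond the scatter). No measurement here accounts for that difference. The compounds shown leave open whether chlorine or a nitrile in place of the added fluorine would give a similar number, and whether the 3,6-difluoro-2-methoxyphenyl group would do so alongside the trifluoromethyl group of compound 1.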